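The compounds below may be only part of what the source reports. "The series", "measured", "known", "first", "only" and "open" are said of these compounds alone.

Compound 1 `CN(C)c1nc2c(Cl)c(Cl)ccc2n1COC(CO)CO`: in a functional assay on KB cells (Homo sapiens) for inhibition (a higher number here means a weaker inhibitor, a lower number a stronger inhibitor), compound 1 gives > 100000 nM, which is a limit of the assay.
Compound 2 `OCC(CO)OCn1c(SCc2ccccc2)nc2c(Cl)c(Cl)ccc21`: in this assay compound 2 gives 60000 nM.
Compound 3 `OCC(CO)OCn1cnc2c(Cl)c(Cl)ccc21`: in this assay compound 3 gives > 100000 nM, again a limit and not a number.

Compound 3 therefore stands at the ceiling of this assay, where two of the three values sit (the limit of > 100000 nM in this assay, at which 2 of the 3 values shown sit). Only compound 2 returns a real number. The step of an at least 1.6-fold higher number from compound 2 to compound 3 (0.22 log units; that floor lies within the scatter) shows that taking benzylsulfanyl away leaves the compound no more potent, and the floor of that step sits within the scatter. The step that the two limits leave unreadable from compound 1 to compound 3 cannot be read at all, as both ends are limits.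

Compound 4 `OCC(CO)OCn1c(Br)nc2c(Cl)c(Cl)ccc21` differs from compound 3 by bromo in place of hydrogen on an aromatic carbon. The two measured steps that bear on it both exchange a group at this same carbon for hydrogen, and neither shows a clear gain from a substituent there: dimethylamino in compound 1 stays at the limit, benzylsulfanyl in compound 2 reaches only a modest number. A single bromine is expected to behave no better, so the step of a number no higher from compound 3 to compound 4 (the limit leaves the size open) is expected to stay within the scatter. Compound 4 is estimated at 100000 nM, with a range from 30000 nM to 300000 nM.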

Compound 4, half-maximal inhibitory concentration: > 100000 nM
Compound 4: only a limit was reported; the forecaster's own chance of this, stated with the estimate: 60%; the middle value lies on the limit itself.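

In this assay compound 4 gives > 100000 nM, which is a limit of the assay and not a number. Bromo on the aromatic carbon between two ring nitrogen atoms thus adds a third group at this carbon that yields no measurable potency, after hydrogen and dimethylamino, and the series now piles up at one ceiling: the limit of > 100000 nM in this assay, at which 3 of the 4 values shown sit. Benzylsulfanyl remains the only group here to return a real number, and the change to bromo gives an at least 1.6-fold higher number from compound 2 to compound 4 (0.22 log units; that floor lies within the scatter), so even this comparison shows no firm difference, while the steps from compound 1 and compound 3 to compound 4 cannot be read, since both ends of each are limits.

On these data alone, whether any group at this carbon can bring a clear gain in potency stays open, as a single real number near the ceiling offers little to compare against. A phenyl ring, a carboxylic acid or a longer chain carrying a sulfur atom at this carbon would show whether the measurable value of compound 2 can be improved on, or whether it stands alone.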